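Substituent change at the pendant ring: compound 3 to compound 4

The source may report more compounds than this note shows. Statements on the series, on what has been measured and on what is new or still open speak of the compounds shown alone.

Measured in an assay on LM cells for displacement of a labelled ligand from Neuropeptide Y receptor type 5 (Homo sapiens); on this read-out higher numbers stand for weaker inhibition and lower numbers for stronger inhibition:
compound 1, `Fc1ccc(C2(c3ccc(F)cc3)CNC(c3cccc(Cl)c3)=N2)cc1` — 5.4 nM
compound 2, `Fc1ccc(C2(c3ccc(F)cc3)CNC(c3cccc(F)c3)=N2)cc1` — 10 nM
compound 3, `O=[N+]([O-])c1cccc(C2=NC(c3ccc(F)cc3)(c3ccc(F)cc3)CN2)c1` — 4.3 nM

Going by the values given here, compound 3 gives the lowest of the three numbers in this assay, but only one of its neighbours is separated from it beyond the scatter: the steps are a 1.3-fold lower number from compound 1 to compound 3 (0.10 log units; within the scatter) and a 2.3-fold lower number from compound 2 to compound 3 (0.37 log units; beyond the scatter). Compound 3 cannot therefore be called the most potent of the set outright.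

Compound 4 is `CC(=O)c1cccc(C2=NC(c3ccc(F)cc3)(c3ccc(F)cc3)CN2)c1`. The change from compound 3 is acetyl in place of nitro on an aromatic carbon. Among the compounds with values here, no measured step swaps nitro for acetyl. Within the data shown here, the steps that bear on this position are a 1.9-fold higher number from compound 1 to compound 2 (0.27 log units; within the scatter), a 1.3-fold lower number from compound 1 to compound 3 (0.10 log units; within the scatter) and a 2.3-fold lower number from compound 2 to compound 3 (0.37 log units; beyond the scatter): three different groups at the same place give numbers that stay close together, with only one pair beyond the scatter. A step of similar small size is therefore expected for compound 4, with an upward direction somewhat more likely than not, since compound 3 already holds the lowest number. Compound 4 is estimated at 7 nM, with a range of 2.5 nM to 20 nM. This estimate means a step of a 1.6-fold higher number from compound 3 to compound 4 (0.21 log units; within the scatter), expected to remain within the scatter.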

Compound 4, half-maximal inhibitory concentration: 44 nM
Compound 4: the middle estimate sits 6.3-fold (0.80 log units) below what was measured; measured number outside the range, above it.
By their numbers in this assay, from the lowest: compounds 3, 1 and 2 (each within the scatter of the next, the first and the last beyond it); then compound 4.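

In this assay this position proves less permissive than the chloro, fluoro and nitro compounds alone suggested: acetyl separates clearly from all three, with a 10-fold higher number from compound 3 to compound 4 (1.01 log units; beyond the scatter) and an 8.1-fold higher number from compound 1 to compound 4 (0.91 log units; beyond the scatter) and a 4.4-fold higher number from compound 2 to compound 4 (0.64 log units; beyond the scatter). So the close numbers of the earlier compounds do not extend to every group placed here, and the largest step is the one between nitro and acetyl. Those two groups have equal heavy-atom counts, so that count does not track the step, and no measurement in hand accounts for the separation of acetyl from the other groups.

From the compounds shown here alone, whether the higher number goes with the carbonyl or with the methyl of acetyl stays open. A formyl, a methyl ester, an amine or a carboxylic acid at this place would help to separate those readings.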